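A few compounds are considered here, and "the series" means these few. Any claim that something is new, unique, unknown or untested is made for them only; others in the source may bear on it.

Measured so far in an ADME assay on MT4 cells (Homo sapiens) for cytotoxicity, read by MTT assay; on this read-out lower numbers stand for higher toxicity in this test and higher numbers for lower toxicity in this test:
- compound 1, `O=C(CSc1nncnc1-c1ccccc1Cl)c1ccc(Cl)c(Cl)c1`, gives 33000 nM
- compound 2, `CCOC(=O)c1ccc(NC(=O)CSc2nncnc2-c2ccccc2Cl)c(Br)c1`, gives 69000 nM
- compound 3, `O=C(CSc1nncnc1-c1ccccc1Cl)Nc1ccccc1Cl`, gives 90000 nM

Compound 3 has the highest of the three numbers in this assay. The gap to compound 2 is within the scatter, so the two are not distinguishable here. For the measured compounds named here, the only step beyond the scatter is a 2.7-fold higher number from compound 1 to compound 3 (0.44 log units; beyond the scatter), the change being (2-chlorophenyl)amino in place of 3,4-dichlorophenyl on a carbonyl carbon.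

Compound 4, `O=C(CSc1nncnc1-c1ccccc1Cl)Nc1ccccc1Br`, differs from compound 3 by bromo in place of chloro on an aromatic carbon. Going by the values given here, no measured pair isolates this exchange: compound 2 carries a bromo as well, but it differs from compound 3 in other places too, and no single step between them exists, so its value says little about bromo against chloro alone. Among the compounds with values here, the one measured step concerns a different change and does not bear on this one. With nothing in the data pointing either way, the expectation for compound 4 is a number close to that of compound 3, with no step beyond the scatter, estimated as no change at the digits printed from compound 3 to compound 4 (within the scatter).

For compound 4 in this assay the estimate is 90000 nM, with a range from 45000 nM to 180000 nM.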

Compound 4, half-maximal cytotoxic concentration: 73000 nM
Compound 4: the middle estimate sits 1.2-fold (0.09 log units) above what was measured; the measured number falls inside the stated range.
By their numbers in this assay, from the lowest: compound 1; then compounds 2, 4 and 3 (each within the scatter of the next).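

In this assay, bromo in place of chloro on an aromatic carbon, ortho to a large group, gives a 1.2-fold lower number from compound 3 to compound 4 (0.09 log units; within the scatter), so the two halogens are not told apart at this place on this read-out. Hydrogen in place of ethoxycarbonyl on an aromatic carbon gives a 1.1-fold higher number from compound 2 to compound 4 (0.02 log units; within the scatter), the first single-place reading for that group, and it too stays within the scatter. Swapping the 3,4-dichlorophenyl of compound 1 for the (2-bromophenyl)amino group gives a 2.2-fold higher number from compound 1 to compound 4 (0.34 log units; beyond the scatter), which runs in the same direction as a 2.7-fold higher number from compound 1 to compound 3 (0.44 log units; beyond the scatter), so the separation of compound 1 holds with either halogen on the 2-position of the phenyl ring.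

As far as these compounds go, whether a methoxy group or an amine at the halogen's place, or a carboxylic acid in place of ethoxycarbonyl, would shift the number beyond the scatter remains open. The data shown also hold no measurement that accounts for any of these numbers.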